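From an ethoxyethyl ether to a 4-chlorobenzyl ether

This account rests on a few compounds, and the source may have more. Where it says the series, first, only, none or still open, it means among the compounds named here.

Measured in an ADME assay on RAW264.7 cells (Mus musculus) for cytotoxicity, read by MTT assay, with a stated time of 24 h, in the presence of a further agent that is not named here; a higher number here means a weaker inhibitor, a lower number a stronger inhibitor:
Compound 1 `CCCCOc1ccc(C(O)C2OC(=O)c3c(OC)cc(OC)cc32)cc1`: > 40000 nM
Compound 2 `COCCOc1ccc(C(O)C2OC(=O)c3c(OC)cc(OC)cc32)cc1`: > 40000 nM
Compound 3 `CCOCCOc1ccc(C(O)C2OC(=O)c3c(OC)cc(OC)cc32)cc1`: > 40000 nM

Compound 3 gives > 40000 nM in this assay and this is a limit, not a number. It stands with the other two compounds, and none of the three can be ranked (the limit of > 40000 nM in this assay, at which 3 of the 3 values shown sit).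

Compound 4 (`COc1cc(OC)c2c(c1)C(C(O)c1ccc(OCc3ccc(Cl)cc3)cc1)OC2=O`) carries 4-chlorophenyl in place of ethoxymethyl on a saturated chain carbon bound to an oxygen on an aromatic ring. Cut one bond further out, 2-ethoxyethoxy gives way to (4-chlorobenzyl)oxy.

The measured changes on this chain are a step that the two limits leave unreadable from compound 1 to compound 2 and a step that the two limits leave unreadable from compound 1 to compound 3 and also a step that the two limits leave unreadable from compound 2 to compound 3 and none of them has a size that can be read. None of them brings a ring into the chain, so they offer no direct guide to the entering group. Holding to compound 3 and the shared limit (the limit of > 40000 nM in this assay, at which 3 of the 3 values shown sit), the step expected is a step that the limit leaves unreadable from compound 3 to compound 4 and in this assay no move beyond the scatter, in either direction, is foreseen. A report of only a limit is the likeliest outcome. For compound 4 the estimated value is 45000 nM with an expected range running (20000 nM to 100000 nM).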

Compound 4, half-maximal inhibitory concentration: > 40000 nM
Compound 4: no number, only a limit (the forecaster's own chance of this, stated with the estimate: 80%); the middle value is on the limit's open side.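

In this assay compound 4 gives > 40000 nM, which is a limit and not a number, so no new step can be read between it and compound 1, compound 2 or compound 3: the limit of > 40000 nM in this assay, at which 4 of the 4 values shown sit.

The compounds shown leave open how far these four differ from one another in this assay, and whether any ether on this chain would give a readable value there.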